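Acetylating a hydroxy group in a weak compound

A few compounds are considered here, and "the series" means these few. Any claim that something is new, unique, unknown or untested is made for them only; others in the source may bear on it.

Measured in an ADME assay on MIA PaCa-2 cells (Homo sapiens) for cytotoxicity, read by MTT assay, with a stated time of 72 h; a lower number here means a stronger inhibitor, a higher number a weaker inhibitor:
- compound 1 `COc1ccc(C2=C(c3cc(OC)c(OC)c(OC)c3)C(=O)C(OC(C)=O)C2)cc1`: < 1 ug/mL, a limit of the assay and not a number
- compound 2 `COc1ccc(C2=C(c3cc(OC)c(OC)c(OC)c3)C(=O)C(O)C2)cc1Cl`: > 100 ug/mL, a limit of the assay and not a number

Compound 2 sits at the limit of > 100 ug/mL in this assay, at which 1 of the 2 values shown sits. Going by these compounds, its true value therefore remains unknown, and any step that starts from compound 2 can only be estimated loosely.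

Compound 3 `COc1ccc(C2=C(c3cc(OC)c(OC)c(OC)c3)C(=O)C(OC(C)=O)C2)cc1Cl` is compound 2 with one change, hydroxy to acetoxy: acetyl in place of hydrogen on an oxygen on a saturated carbon. In words, acetyl takes the place of hydrogen on an oxygen on a saturated carbon.

Going by the values given here, no measured step between two compounds is available as a guide. Among the compounds with values here, the only hint comes from compound 1, which also carries the acetoxy group and reads < 1 ug/mL. On that reading, a large move towards a stronger inhibitor is expected in this assay, well beyond the scatter. The expected step, an at least 33-fold lower number from compound 2 to compound 3 (1.52 log units; beyond the scatter), rests on this single comparison, so the estimated range is kept wide. Compound 3 is estimated at 3 ug/mL, with an expected range of 0.5 ug/mL to 40 ug/mL.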

Compound 3, half-maximal inhibitory concentration: 24 ug/mL
For compound 3 the middle estimate is 8.0-fold (0.90 log units) below the measured one, within the range that was stated.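

Replacing hydroxy with acetoxy on the chlorinated compound does help in this assay, with an at least 4.1-fold lower number from compound 2 to compound 3 (0.61 log units; beyond the scatter), but adding the chloro group to the acetoxy compound gives an at least 24-fold higher number from compound 1 to compound 3 (1.38 log units; beyond the scatter), so the acetoxy group alone does not secure the strong reading of compound 1. The size of the first step is only a minimum, because compound 2 stands at a limit of the assay and not at a number: the limit of > 100 ug/mL in this assay, at which 1 of the 3 values shown sits. The size of the second step is also only a minimum, because compound 1 likewise stands at a limit of the assay: the limit of < 1 ug/mL in this assay, at which 1 of the 3 values shown sits.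

The compounds shown leave open whether a longer chain on that oxygen, such as a butanoyl ester, or an amine-bearing acyl group would read closer to compound 1 or to compound 2. They also leave open whether a smaller atom such as fluorine, or a methyl group, in place of the chloro group would carry the same penalty as chloro does when the acetoxy group is present.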